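Chloro at a new ring position on the shared core

This account rests on a few compounds, and the source may have more. Where it says the series, first, only, none or still open, it means among the compounds named here.

Compound 3 `O=C(CCCc1ccccc1)Nc1nc2ccccc2c(=O)s1` carries the unsubstituted core, and in an assay on CHO cells for displacement of a labelled ligand from adenosine receptor A3 (Homo sapiens), read by scintillation counting, with a stated time of 60 min (on this read-out lower numbers stand for stronger inhibition and higher numbers for weaker inhibition), compound 3 gives > 1000 nM, which is a limit of the assay rather than a number. Compound 1 `COc1cccc(CCCC(=O)Nc2nc3ccccc3c(=O)s2)c1` gives 382 nM in this assay, and compound 2 `O=C(CCCc1ccccc1)Nc1nc2cc(Cl)ccc2c(=O)s1` gives 91.6 nM. The measured steps of an at least 2.6-fold higher number from compound 1 to compound 3 (0.41 log units; beyond the scatter) and an at least 10-fold higher number from compound 2 to compound 3 (1.03 log units; beyond the scatter) both end at the limit of > 1000 nM in this assay, at which 1 of the 3 values shown sits, so only their minimum sizes are known. Compound 4 `O=C(CCCc1ccccc1)Nc1nc2ccc(Cl)cc2c(=O)s1` differs from compound 3 by chloro in place of hydrogen on an aromatic carbon. Within the data shown here, the closest measured step is the one from compound 2 to compound 3, where removing chloro from an aromatic carbon raised the number by at least a large amount; compound 4 places chloro on a different aromatic carbon of the same ring, so that step is a guide only in direction. The account therefore expects a lower number, toward stronger inhibition, for compound 4, estimated as an at least 3.3-fold lower number from compound 3 to compound 4 (0.52 log units; beyond the scatter). Compound 4 is estimated in this assay at 300 nM, with a plausible range of 80 nM to 1500 nM.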

Compound 4, inhibition constant: > 1000 nM
Compound 4: no number, only a limit; the forecaster's own chance of this, stated with the estimate: 25%; middle value at least 3.3-fold (0.52 log units) away from the limit.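

In this assay, among these compounds, compound 4 gives > 1000 nM as a limit and not a number, and with compound 3 also at a limit, no step between compound 3 and compound 4 can be read: the limit of > 1000 nM in this assay, at which 2 of the 4 values shown sit. Going by these compounds, whether chloro at this new ring position changes the number at all stays open.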